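Pyridinyloxy variation and passive permeability in the benzimidazole acid series

The compounds below may be only part of what the source reports. "The series", "measured", "known", "first", "only" and "open" are said of these compounds alone.

Measured so far in an ADME assay for permeability, using PAMPA, with a stated time of 4 h; a lower number here means that the compound crosses the layer more slowly, a higher number that the compound crosses the layer faster:
compound 1 `Cn1c(COc2cccc(C(=O)O)c2)nc2ccc(Oc3cc(Cl)ccn3)cc21` gives 10.3 10^-6 cm/s
compound 2 `Cc1ccnc(Oc2ccc3nc(COc4cccc(C(=O)O)c4)n(C)c3c2)c1` gives 3.5 10^-6 cm/s
compound 3 `Cc1cccnc1Oc1ccc2nc(COc3cccc(C(=O)O)c3)n(C)c2c1` gives 6 10^-6 cm/s

Compound 3 sits between the other two, but neither gap is telling: the step of a 1.7-fold lower number from compound 1 to compound 3 (0.23 log units; within the scatter) and the step of a 1.7-fold higher number from compound 2 to compound 3 (0.23 log units; within the scatter) both stay within the scatter, so the three values cannot be ranked against one another with confidence. Among the measured compounds shown here, the only step that does stand beyond the scatter is a 2.9-fold lower number from compound 1 to compound 2 (0.47 log units; beyond the scatter), a swap of methyl for chloro on the pyridinyl ring.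

Compound 4 `Cn1c(COc2cccc(C(=O)O)c2)nc2ccc(Oc3ccc(F)cn3)cc21` is the next member. It differs from compound 3 in one place: 5-fluoropyridin-2-yl in place of 3-methylpyridin-2-yl on an oxygen on an aromatic ring. The two pyridinyl swaps already in hand, from compound 1 to compound 3 and from compound 2 to compound 3, were both small and within the scatter; the step from compound 1 to compound 2 shows that a halogen-bearing ring gave a higher reading than a methyl-bearing one. On that basis the move to a fluorine-bearing ring is expected to give, at most, a modest rise in this assay, or none beyond the scatter. For compound 4 the estimate is 7.5 10^-6 cm/s, with a range from 3.5 10^-6 cm/s to 15 10^-6 cm/s, meaning an expected step of a 1.3-fold higher number from compound 3 to compound 4 (0.10 log units; within the scatter).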

Compound 4, apparent permeability: 4.7 10^-6 cm/s
Estimate against measurement, compound 4: 1.6-fold (0.20 log units) above; the measured number falls inside the stated range.
By their numbers in this assay, from the lowest: compounds 2, 4, 3 and 1 (each within the scatter of the next, the first and the last beyond it).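

In this assay the step of a 1.3-fold lower number from compound 3 to compound 4 (0.11 log units; within the scatter) and the step of a 1.3-fold higher number from compound 2 to compound 4 (0.13 log units; within the scatter) place the 5-fluoropyridin-2-yl ring with both methyl-bearing rings, while the step of a 2.2-fold lower number from compound 1 to compound 4 (0.34 log units; beyond the scatter) sets it apart from the 4-chloropyridin-2-yl ring. A halogen on this ring therefore does not by itself go with the higher reading that compound 1 alone had suggested, and the modest gaps so far all run from compound 1. Compound 3 goes against a clean split of compound 1 from the rest, since its step from compound 1 stays within the scatter, and no measured evidence at hand explains any of these steps.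

The compounds shown leave open whether the gap follows the chlorine or where the halogen sits on the ring, since compound 1 and compound 4 differ in both. In this assay, going by these compounds, the reading of a pyridinyl ring carrying a nitrile or a methoxy group at this place also stays open.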